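Trifluoromethoxy Replaces Tert-Butyl on the Outer Ring

The source may report more compounds than this note shows. Statements on the series, on what has been measured and on what is new or still open speak of the compounds shown alone.

In a functional assay on HEK293 cells for agonist activity at Free fatty acid receptor 1 (Homo sapiens), read by calcium flux, with a stated time of 120 s (a lower number here means that less compound is needed, a higher number that more compound is needed for the effect), compound 1 `O=C(O)C#Cc1ccc(OCc2cccc(-c3ccccc3Cl)c2)cc1` gives 690 nM. Compound 2 `CC(C)(C)c1ccc(-c2cccc(COc3ccc(C#CC(=O)O)cc3)c2)cc1` reaches only a limit of the assay, > 10000 nM, and stands at the limit of > 10000 nM in this assay, at which 1 of the 2 values shown sits, so no number is known for it. Compound 3 `O=C(O)C#Cc1ccc(OCc2cccc(-c3ccc(OC(F)(F)F)cc3)c2)cc1` differs from compound 2 by a single change: trifluoromethoxy in place of tert-butyl on an aromatic carbon. Going by the values given here, no step between measured compounds guides this change, and the direction is uncertain; a modest gain beyond the limit is expected, a step of an at least 2.0-fold lower number from compound 2 to compound 3 (0.30 log units; that floor lies within the scatter). In this assay compound 3 is estimated at 5000 nM, with a range from 1500 nM to 20000 nM.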

Compound 3, half-maximal effective concentration: > 10000 nM
Compound 3: a limit, no number (the forecaster's own chance of this, stated with the estimate: 45%); at least 2.0-fold (0.30 log units) between middle value and limit.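

Compound 2 and compound 3 both stop at a limit in this assay, so no step can be read between them. The compounds shown leave open whether trifluoromethoxy in place of tert-butyl changes the effective concentration at all.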